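Propyl Substitution on the Aryl Ring of Compound 1

The source may hold more compounds than are shown below. What is called first, only, known or untested is meant among the compounds shown, and "the series" means these compounds.

Measured so far:
compound 1 `O=C(CCCCCCc1ccccc1)N1CCCC1`, 12900 nM
compound 2 `COc1ccc(CCCCCCC(=O)N2CCCC2)cc1`, 35400 nM

Of the compounds shown here, two have been measured in an assay on HEK293 cells for inhibition of N-acylethanolamine-hydrolyzing acid amidase (Rattus norvegicus), read by LC-MS, with a stated time of 30 min; on this read-out higher numbers stand for weaker inhibition and lower numbers for stronger inhibition. Compound 1 `O=C(CCCCCCc1ccccc1)N1CCCC1` gives 12900 nM and compound 2 `COc1ccc(CCCCCCC(=O)N2CCCC2)cc1` gives 35400 nM. Compound 1 thus holds the lowest of the two numbers in this assay; its nearest neighbour is compound 2, and the step of a 2.7-fold higher number from compound 1 to compound 2 (0.44 log units; beyond the scatter) is beyond the scatter, so a methoxy group on the aromatic ring weakened inhibition to a modest degree.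

The step to compound 3 `CCCc1cccc(CCCCCCC(=O)N2CCCC2)c1` is different: propyl in place of hydrogen on an aromatic carbon. Going by the values given here, no measured step bears directly on a propyl group at this place; the only change seen on the aromatic ring is the methoxy of compound 2, which is a different group at a different position and cannot be carried over. Among the compounds with values here, the one measured step on this ring was modest in size, so a change of similar or smaller size is expected in this assay, with the direction uncertain. Compound 3 is therefore estimated at 15000 nM, within 5000 nM to 45000 nM, which means an expected step of a 1.2-fold higher number from compound 1 to compound 3 (0.07 log units; within the scatter).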

Compound 3, half-maximal inhibitory concentration: > 100000 nM
Compound 3 gave a limit, no number; the forecaster's own chance of this, stated with the estimate: 15%; middle value at least 6.6-fold (0.82 log units) from the limit.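

In this assay, compound 3 gave a limit and not a number: the limit of > 100000 nM in this assay, at which 1 of the 3 values shown sits.

The limit still fixes a direction for this position: propyl in place of hydrogen on an aromatic carbon, meta to a large group, gives an at least 7.7-fold higher number from compound 1 to compound 3 (0.88 log units; beyond the scatter), so this change weakened inhibition, and it reaches further than the modest 2.7-fold higher number from compound 1 to compound 2 (0.44 log units; beyond the scatter). Compound 1, which carries hydrogen at both places, therefore keeps the lowest number of the three, and neither group placed on its aromatic ring so far has given stronger inhibition.

As far as these compounds go, a limit cannot show how far the true value of compound 3 lies from that of compound 1, and the two ring changes differ in both group and place, so it remains open whether the propyl group itself or the place it occupies matters more. A smaller group such as methyl or a fluorine atom at this same place, or propyl at the place held by the methoxy of compound 2, would help to separate these two questions.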